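Clearance notes: from compound 3 to compound 4

The source may hold more compounds than are shown below. What is called first, only, known or untested is meant among the compounds shown, and "the series" means these compounds.

Values in an ADME assay on microsomes from liver (Homo sapiens) for metabolic stability; a higher number here means faster removal of the compound, a lower number slower removal:
- compound 1 `CC(=O)N[C@@H]1CCC[C@H](C(=O)Nc2cc(-c3cnn4c3CCCC4)ccn2)C1`: < 3 mL.min-1.g-1 (a limit)
- compound 2 `CC(=O)N[C@@H]1CCC[C@H](C(=O)Nc2cc(-c3cnn4c3CCCC4)c(F)cn2)C1`: < 3 mL.min-1.g-1 (a limit)
- compound 3 `CC(=O)N[C@@H]1CCC[C@H](C(=O)Nc2cc(-c3cnc4n3CCCC4)c(Cl)cn2)C1`: 16 mL.min-1.g-1

In this assay, among the measured compounds shown here, compound 3 gives 16 mL.min-1.g-1, the only number among the three. The other two values are limits. Compound 4 `CC(=O)N[C@@H]1CCC[C@H](C(=O)Nc2cc(-c3cnn4c3COCC4)c(Cl)cn2)C1` changes one group: a group of 9 heavy atoms (6 carbon, 2 nitrogen, 1 oxygen; one five-membered aromatic ring with 2 hetero atoms, one six-membered non-aromatic ring with 2 hetero atoms) in place of a group of 9 heavy atoms (7 carbon, 2 nitrogen; one five-membered aromatic ring with 2 hetero atoms, one six-membered non-aromatic ring with 1 hetero atom), on an aromatic carbon. For the measured compounds named here, no measured step covers this change. Going by the values given here, the one step in hand, a step that the two limits leave unreadable from compound 1 to compound 2, lies elsewhere on the structure and gives no size. The nearest guide is structural: compound 4 shares its five-membered ring arrangement with compound 1 and compound 2, which both sit at the limit of < 3 mL.min-1.g-1 in this assay, at which 2 of the 3 values shown sit. Neither carries the chloro group of compound 3, so the comparison is loose. The expected step, toward slower removal, is a 2.7-fold lower number from compound 3 to compound 4 (0.43 log units; beyond the scatter). Compound 4 is estimated at 6 mL.min-1.g-1, with an expected range of 3 mL.min-1.g-1 to 14 mL.min-1.g-1.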

Compound 4, intrinsic clearance in microsomes: < 3 mL.min-1.g-1
Compound 4: only a limit was reported (the forecaster's own chance of this, stated with the estimate: 35%); middle value at least 2.0-fold (0.30 log units) away from the limit.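

With the chloro group in place, the group on the aromatic carbon opposite the ring nitrogen matters in this assay: the exchange gives an at least 5.3-fold lower number from compound 3 to compound 4 (0.72 log units; beyond the scatter). Among the compounds shown here, the earlier compounds held no step at this position, and their one step cannot be read. Compound 4 gives only a limit and joins the floor of the assay: the limit of < 3 mL.min-1.g-1 in this assay, at which 3 of the 4 values shown sit.

Open, on these data alone, is how much of the step belongs to the added ring oxygen and how much to the different arrangement of the five-membered aromatic ring. Also open, as far as these compounds go, is whether an amine nitrogen in place of that oxygen would stay at the limit.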